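Swapping a Cyclopropyl Ketone for a Fluorophenyl Ketone

A few compounds are considered here, and "the series" means these few. Any claim that something is new, unique, unknown or untested is made for them only; others in the source may bear on it.

Measured so far:
Compound 1, `COc1cc(-c2nnc3n2NC(c2cccs2)C(C(=O)c2ccccc2)S3)cc(OC)c1OC`, gives > 100000 nM in a functional assay on MCF7 cells (Homo sapiens) for cytotoxicity, read by MTT assay, with a stated time of 48 h; a higher number here means a weaker inhibitor, a lower number a stronger inhibitor; this is a limit of the assay, not a number.
Compound 2, `COc1cc(-c2nnc3n2NC(c2ccco2)C(C(=O)C2CC2)S3)cc(OC)c1OC`, gives > 100000 nM in this assay; this too is a limit of the assay.
Compound 3, `COc1ccc(C(=O)C2Sc3nnc(-c4cc(OC)c(OC)c(OC)c4)n3NC2c2cccs2)cc1`, gives 49500 nM in this assay.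

Compound 2 therefore stands at the assay limit, a position it shares with another compound (the limit of > 100000 nM in this assay, at which 2 of the 3 values shown sit), so no true number is known for it. For the measured compounds named here, the one measured step, an at least 2.0-fold lower number from compound 1 to compound 3 (0.30 log units; that floor lies within the scatter), comes from methoxy in place of hydrogen on an aromatic carbon and touches a different part of the shared core than the change now in question. The unmeasured compound 4, `COc1cc(-c2nnc3n2NC(c2ccco2)C(C(=O)c2ccccc2F)S3)cc(OC)c1OC`, differs from compound 2 as follows: 2-fluorophenyl in place of cyclopropyl on a carbonyl carbon. Going by the values given here, no measured step tests this swap directly. Compound 1 and compound 3 already carry an aromatic ring on that carbonyl carbon, and neither reaches a strong value, so a large gain is not expected. Compound 4 is expected to give 90000 nM in this assay, within 30000 nM to 250000 nM, meaning an expected step of an at least 1.1-fold lower number from compound 2 to compound 4 (0.04 log units; that floor lies within the scatter) that most likely stays at or near the limit.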

Compound 4, half-maximal inhibitory concentration: 94800 nM
Compound 4: the middle estimate sits 1.1-fold (0.02 log units) below what was measured, within the range that was stated.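

The swap of cyclopropyl for 2-fluorophenyl on a carbonyl carbon gives an at least 1.0-fold lower number from compound 2 to compound 4 (0.02 log units; that floor lies within the scatter). From the compounds shown here alone, compound 2 holds only a limit of the assay, so the true size of this step stays unknown: the limit of > 100000 nM in this assay, at which 2 of the 4 values shown sit. Unlike compound 2, compound 4 gives a true number in this assay, which offers a firm point of comparison for later changes at this position, but the step shows no gain beyond the scatter.

Going by these compounds, it remains open whether the fluorine itself matters to this number, compared with a plain phenyl or a chlorine on the same ring. On these data alone, it is also open whether a quite different group on that carbonyl carbon, such as an amine or a longer carbon chain, would move the value clearly away from the limit.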